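Carbamate to Aminoamide on the Ring Nitrogen: Compound 4

A few compounds are considered here, and "the series" means these few. Any claim that something is new, unique, unknown or untested is made for them only; others in the source may bear on it.

Measured so far in a functional assay on the whole organism for inhibition of sodium-dependent dopamine transporter (Mus musculus); a higher number here means that more compound is needed for the effect, a lower number that less compound is needed:
compound 1 `Cc1ccc(C2CN(C)Cc3c(N)cccc32)cc1` — about 22 mg/kg
compound 3 `CN1Cc2c(NC(=O)OCc3ccccc3)cccc2C(c2ccccc2)C1` — 25 mg/kg
Compound 2 `CCCCNC(=O)Nc1cccc2c1CN(C)CC2c1ccc(C)cc1` gives only a limit, > 100 mg/kg.

Compound 3 stands highest of the two numbers, with compound 1 nearest and within the scatter. Compound 2 sits at the limit of > 100 mg/kg in this assay, at which 1 of the 3 values shown sits. Compound 4 `CC(C)NCCC(=O)Nc1cccc2c1CN(C)CC2c1ccccc1` differs from compound 3 by 2-(isopropylamino)ethyl in place of benzyloxy on a carbonyl carbon. Within the data shown here, the only step that bears on this change is an at least 4.5-fold higher number from compound 1 to compound 2 (0.65 log units; beyond the scatter), where a carbamoyl group on the same ring nitrogen raised the number at least modestly; the benzyloxycarbonyl of compound 3, by contrast, leaves it where compound 1 is. The outcome for an amide carrying a 2-(isopropylamino)ethyl chain is therefore open. Compound 4 is estimated at 30 mg/kg, between 10 mg/kg and 100 mg/kg. This estimate means a step of a 1.2-fold higher number from compound 3 to compound 4 (0.08 log units; within the scatter), expected to stay within the scatter.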

Compound 4, dose for half-maximal effect: about 200 mg/kg
Compound 4: middle estimate off by 6.7-fold (0.82 log units), on the low side; measured number outside the range, above it.
By their numbers in this assay, from the lowest: compounds 1 and 3 (each within the scatter of the next); then compound 4.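

On a carbonyl carbon whose other neighbour is an amide-type nitrogen, the group matters: in this assay, 2-(isopropylamino)ethyl in place of benzyloxy gives an 8.0-fold higher number from compound 3 to compound 4 (0.90 log units; beyond the scatter). A carbonyl at this place therefore does not by itself hold the number at the level of compound 3. The value of compound 2 is only a limit: the limit of > 100 mg/kg in this assay, at which 1 of the 4 values shown sits.

The compounds shown do not separate the loss of the aromatic ring from the entry of the chain's nitrogen. A phenethyl group or a plain pentyl chain on this carbonyl carbon would bear on that question.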